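The source may hold more compounds than are shown below. What is called first, only, known or untested is meant among the compounds shown, and "the series" means these compounds.

Compounds measured so far in a functional assay on HEK293 cells for antagonist activity at transient receptor potential cation channel subfamily V member 1 (Rattus norvegicus); on this read-out lower numbers stand for stronger inhibition and higher numbers for weaker inhibition:

Compound 1, `CC(C)(C)c1ccc(NC(=O)N2CCN(c3ncccc3C(F)(F)F)CC2)cc1`: 57.7 nM
Compound 2, `CC(C)c1ccc(NC(=O)N2CCN(c3ncccc3[N+](=O)[O-])CC2)cc1`: 245 nM
Compound 3, `CC(C)c1ccc(NC(=O)N2CCN(c3ncccc3Cl)CC2)cc1`: 17.3 nM

Among these three, compound 3 stands lowest in this assay: compound 1 sits a step above it that is beyond the scatter, and compound 2 lies furthest away. Among the measured compounds shown here, the one single-point step that has been measured is the one from compound 2 to compound 3, where a 14-fold lower number from compound 2 to compound 3 (1.15 log units; beyond the scatter) accompanied the swap of chloro for nitro on the pyridine ring.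

Compound 4, `CC(C)c1ccc(NC(=O)N2CCN(c3ncccc3Br)CC2)cc1`, takes the same pyridine position one step further: bromo in place of chloro on an aromatic carbon. For the measured compounds named here, no measured step in this set exchanges one halogen for another, so the large step from compound 2 to compound 3 only shows that this position is sensitive to what sits on it; it does not tell which way a chloro-to-bromo swap goes. Both groups are single heavy atoms without donors or acceptors, so the expected change is small. For compound 4 the expected step in this assay is a 1.2-fold lower number from compound 3 to compound 4 (0.06 log units; within the scatter), within the scatter. Compound 4 is therefore estimated at 15 nM, with a range from 6 nM to 40 nM.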

Compound 4, half-maximal inhibitory concentration: 27.1 nM
For compound 4 the middle estimate is 1.8-fold (0.26 log units) below the measured one, within the range that was stated.
By their numbers in this assay, from the lowest: compounds 3 and 4 (each within the scatter of the next); then compound 1; then compound 2.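

In this assay, bromo in place of chloro gives a 1.6-fold higher number from compound 3 to compound 4 (0.19 log units; within the scatter) and so cannot be told apart from chloro on this measurement: at this position, going from 3-chloropyridin-2-yl to 3-bromopyridin-2-yl leaves the number where it was, within the usual scatter. The large gap to the nitro compound is also not peculiar to chloro, since bromo in place of nitro gives a 9.0-fold lower number from compound 2 to compound 4 (0.96 log units; beyond the scatter) and both halogens stand clear of nitro. Nothing measured here explains why the two halogens sit together or why nitro stands apart.

On these data alone, whether fluoro, a methyl group or a plain hydrogen at this position would stay with chloro and bromo remains open. So does the fate of an amine or a methoxy group there, with the rest of the molecule unchanged.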